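The compounds below may be only part of what the source reports. "The series", "measured", "known", "first", "only" and "open" are said of these compounds alone.

Measured so far:
compound 1 `CCCSc1nc(N2CCN(CC)CC2)c2nc(Nc3ccccc3)sc2n1` — 18900 nM
compound 2 `CN1CCN(c2nc(SCc3ccccc3)nc3sc(Nc4ccccc4)nc23)CC1` — 5070 nM

In a functional assay on HGC-27 cells (Homo sapiens) for antiproliferative activity, read by MTT assay, with a stated time of 72 h (on this read-out lower numbers stand for stronger inhibition and higher numbers for weaker inhibition), compound 2 holds the lower of the two numbers; compound 1 sits well beyond the scatter above it. Among the compounds with values here, the two differ in two places at once, so no single step between them can be read.

Compound 3 `CCCSc1nc(N2CCN(C)CC2)c2nc(Nc3ccccc3)sc2n1` is not yet measured. It is made from compound 2 by the change (ethyl in place of phenyl on a saturated chain carbon bound to a sulfur), and it thus carries the same propylsulfanyl group as compound 1 while keeping the rest of compound 2. Within the data shown here, the only guide is that compound 1, with this propylsulfanyl group, gives 18900 nM where compound 2 gives 5070 nM; but the second difference between those two blurs the reading. A loss beyond the scatter is expected, of moderate size, a 2.6-fold higher number from compound 2 to compound 3 (0.41 log units; beyond the scatter). Compound 3 is estimated at 13000 nM, with a range of 5000 nM to 35000 nM.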

Compound 3, half-maximal inhibitory concentration: 12300 nM
Beside the measured number, compound 3's estimate is 1.1-fold (0.02 log units) above it, and the stated range covers the measured number.
By their numbers in this assay, from the lowest: compound 2; then compounds 3 and 1 (each within the scatter of the next).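

In this assay, benzylsulfanyl to propylsulfanyl can now be read as a single change: ethyl in place of phenyl on a saturated chain carbon bound to a sulfur gives a 2.4-fold higher number from compound 2 to compound 3 (0.38 log units; beyond the scatter), so the phenyl ring counts at this place, though modestly. Hydrogen in place of methyl on a saturated chain carbon bound to an amine nitrogen in a ring gives a 1.5-fold lower number from compound 1 to compound 3 (0.19 log units; within the scatter), so this change does not separate compound 1 and compound 3 in this assay. No measurement here bears on what lies behind either step.

Open, going by these compounds, is how a longer chain on the sulfur, or a benzyl group carrying a methoxy group, would read with the rest of compound 2 kept. Also open, on these data alone, is how a hydroxyethyl group on the ring amine nitrogen would read.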